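Chloro for trifluoromethyl: working notes on compound 3

The source may hold more compounds than are shown below. What is called first, only, known or untested is meant among the compounds shown, and "the series" means these compounds.

Measured so far in a functional assay on U-937 cells (Homo sapiens) for antiproliferative activity, with a stated time of 48 h; a higher number here means that more compound is needed for the effect, a lower number that less compound is needed:
- compound 1 `O=C(CCCCCCC(=O)Nc1ccc(O)cc1)NO` gives 6400 nM
- compound 2 `O=C(CCCCCCC(=O)Nc1ccc(C(F)(F)F)cc1)NO` gives 450 nM

Compound 2 holds the lower of the two numbers, and compound 1 sits well above it. The open case is compound 3 `O=C(CCCCCCC(=O)Nc1ccc(Cl)cc1)NO`, which keeps the shared core but has chloro in place of trifluoromethyl on an aromatic carbon, para to a large group (chloro in place of trifluoromethyl on an aromatic carbon).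

Going by the values given here, one measured step bears on this change: a 14-fold lower number from compound 1 to compound 2 (1.15 log units; beyond the scatter), with trifluoromethyl in place of hydroxy. That step is large and shows that a swap at this place can shift this assay strongly. Its guidance is only indirect, since chloro has not yet been measured and hydroxy plays no part in the new change. Among the compounds with values here, with no direct precedent, a modest step is expected, perhaps slightly upward and possibly within the scatter. The expected outcome is a 1.3-fold higher number from compound 2 to compound 3 (0.12 log units; within the scatter) in this assay, an estimate that leaves the number much closer to compound 2 than to compound 1. For compound 3 the estimated value is 600 nM, with an expected range of 220 nM to 1500 nM.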

Compound 3, half-maximal effective concentration: 550 nM
Compound 3: the middle estimate sits 1.1-fold (0.04 log units) above what was measured; low and high end bracket the measured number.
By their numbers in this assay, from the lowest: compounds 2 and 3 (each within the scatter of the next); then compound 1.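

In this assay, chloro in place of trifluoromethyl on an aromatic carbon gives a 1.2-fold higher number from compound 2 to compound 3 (0.09 log units; within the scatter) and so stays within the scatter, which means that at this position one chlorine atom can stand in for the four heavy atoms of trifluoromethyl without a readable change in the number. Chloro in place of hydroxy gives a 12-fold lower number from compound 1 to compound 3 (1.07 log units; beyond the scatter) as a large step, so the large difference from compound 1 is now seen with two groups and is no longer tied to trifluoromethyl alone. No measured finding offers a reason for either step.

Going by these compounds, whether an amine or a carboxylic acid at this same place would give a number near that of compound 1 or near those of compound 2 and compound 3 remains open, and a methoxy group or a bromine atom would test how far the tolerance seen here extends. Also open, on these data alone, is whether the match between chloro and trifluoromethyl would persist with a longer chain in the shared core, or with either group placed elsewhere on the aromatic ring.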